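Changing the Ester Group: From Tert-Butyl to Benzyl

The source may report more compounds than this note shows. Statements on the series, on what has been measured and on what is new or still open speak of the compounds shown alone.

Measured in an assay on membranes from HEK293 cells for displacement of a labelled ligand from adenosine receptor A2b (Homo sapiens), read by scintillation counting, with a stated time of 30 min; on this read-out higher numbers stand for weaker inhibition and lower numbers for stronger inhibition:
Compound 1, `CCCOC(=O)C1=C(C)NC(=O)NC1c1ccoc1`: 1190 nM
Compound 2, `CC1=C(C(=O)OC(C)(C)C)C(c2ccoc2)NC(=O)N1`: 4440 nM

Among the measured compounds shown here, compound 2 stands at the highest of the two numbers so far, and its only neighbour is compound 1. For the measured compounds named here, the single measured step, a 3.7-fold higher number from compound 1 to compound 2 (0.57 log units; beyond the scatter), came from putting tert-butyl in place of propyl on an oxygen next to a carbonyl group, so this position is one where a change in the ester group has already shifted the result beyond the scatter.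

Compound 3, `CC1=C(C(=O)OCc2ccccc2)C(c2ccoc2)NC(=O)N1`, differs from compound 2 in that same place: benzyl in place of tert-butyl on an oxygen next to a carbonyl group. The step from compound 1 to compound 2 is the only one that bears on this change, and it shows the size of shift such an ester swap can produce, in the direction of a higher number. Nothing measured tells which way a benzyl group will move the number, so the expectation for compound 3 is a step of modest size, a 2.0-fold lower number from compound 2 to compound 3 (0.30 log units; within the scatter), with wide uncertainty. The estimate for compound 3 in this assay is 2200 nM, within a range from 600 nM to 8000 nM.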

Compound 3, inhibition constant: 6650 nM
Compound 3: the middle estimate sits 3.0-fold (0.48 log units) below what was measured; low and high end bracket the measured number.
By their numbers in this assay, from the lowest: compound 1; then compounds 2 and 3 (each within the scatter of the next).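

On this oxygen next to a carbonyl group, a much larger group does not separate itself from tert-butyl in this assay: benzyl brings a six-membered aromatic ring and 7 heavy atoms against 4, yet the swap gives a 1.5-fold higher number from compound 2 to compound 3 (0.18 log units; within the scatter) and so leaves compound 2 and compound 3 indistinguishable on this read-out. The comparison with the propyl ester is clearer, since phenyl in place of ethyl on the saturated chain carbon gives a 5.6-fold higher number from compound 1 to compound 3 (0.75 log units; beyond the scatter) and this step, like the one to the tert-butyl ester, lies beyond the scatter, so among these three compounds the propyl ester of compound 1 keeps the lowest number. Nothing measured alongside these numbers accounts for why the propyl ester differs from the other two esters.

As far as these compounds go, what remains open is how the number responds to smaller or longer straight chains on this oxygen, such as methyl, ethyl or butyl, and so whether propyl is a real optimum or just the best of three. From the compounds shown here alone, it is equally open what a free carboxylic acid or an amide would do in place of the ester, and whether benzyl rings carrying a chlorine or a methoxy group would behave like plain benzyl.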